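The source may hold more compounds than are shown below. What is called first, only, known or untested is meant among the compounds shown, and "the series" means these compounds.

Compound 1, `CCCCCCCC/C=C\CCCCCCCCCCCC(=O)NCc1ccc(O)c(OC)c1`: 490 nM
Compound 2, `CCCCCCC(=O)CC(O)CCCCCCCCC(=O)NCc1ccc(O)c(OC)c1`: > 10000 nM

Both were tested in an assay on HEK293 cells for antagonist activity at transient receptor potential cation channel subfamily V member 2 (Rattus norvegicus), read by fluorescence and calcium flux, with a stated time of 5 min; a higher number here means a weaker inhibitor, a lower number a stronger inhibitor. Among the compounds with values here, compound 1 gives 490 nM, the only proper number among the two values shown. For compound 2 the assay returns only a limit, > 10000 nM, not a number. That is the limit of > 10000 nM in this assay, at which 1 of the 2 values shown sits. Compound 1 thus stands as the single fixed point from which anything further can be judged.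

Compound 3, `CCCCCCCCCCCCCCCCCCCC(=O)NCc1ccc(O)c(OC)c1`, has not yet been measured. It differs from compound 1 in one place: octyl in place of dec-1-en-1-yl on a saturated chain carbon, ten or more bonds along the chain from a carbonyl carbon. Within the data shown here, no step between measured compounds shares this change, so the expectation rests on compound 1 alone. In this assay a shift no larger than the usual scatter is expected, if anything slightly toward the weaker side. Compound 3 is expected to give about 800 nM, within 250 nM to 3000 nM. That would mean a step of a 1.6-fold higher number from compound 1 to compound 3 (0.21 log units; within the scatter), expected to stay near the scatter.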

Compound 3, half-maximal inhibitory concentration: 3100 nM
For compound 3 the middle estimate is 3.9-fold (0.59 log units) below the measured one; measured number outside the range, above it.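

Until now, nothing showed whether the far end of the chain matters at all in this assay. Octyl in place of dec-1-en-1-yl, on a saturated chain carbon, gives a 6.3-fold higher number from compound 1 to compound 3 (0.80 log units; beyond the scatter) and so makes compound 3 the weaker inhibitor, which shows that even a change this far out on the chain can be read in this assay. The compounds shown offer no measured property that would explain this step.

The change both removes the double bond and shortens the group, so these two effects cannot yet be told apart. A decyl group in the same place would lose the double bond without shortening the group, leaving the role of each still to be settled.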